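The compounds below may be only part of what the source reports. "The series", "measured", "known", "first", "only" and "open" are said of these compounds alone.

Compound 1 `CC#CCN(C)Cc1cc2cc(O)ccc2n1C`: 8800 nM
Compound 2 `C#CCN(C)Cc1cc2cc(O)ccc2n1C`: 820 nM
Compound 3 `C#CCNCc1cc2cc(O)ccc2n1C`: 8900 nM

All three were tested in an assay on isolated protein for inhibition of Amine oxidase [flavin-containing] B (Rattus norvegicus); on this read-out higher numbers stand for weaker inhibition and lower numbers for stronger inhibition. Compound 1 stands second highest of the three numbers. Its nearest neighbour is compound 3 and its furthest is compound 2: a 1.0-fold higher number from compound 1 to compound 3 (0.00 log units; within the scatter), whereas an 11-fold lower number from compound 1 to compound 2 (1.03 log units; beyond the scatter). Compound 4 `CC#CCN(C)Cc1cc2cc(OC)ccc2n1C` differs from compound 1 by methyl in place of hydrogen on an oxygen on an aromatic ring. Going by the values given here, none of the measured steps touches that oxygen: an 11-fold higher number from compound 2 to compound 3 (1.04 log units; beyond the scatter) concerns the amine nitrogen, and the other two steps concern the triple-bonded carbon or the whole amine substituent. The data give no guide for a change at the oxygen. For compound 4 in this assay no step beyond the scatter is expected, a 1.0-fold higher number from compound 1 to compound 4 (0.01 log units; within the scatter). Compound 4 is therefore estimated at 9000 nM, within 3000 nM to 27000 nM.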

Compound 4, inhibition constant: 370 nM
For compound 4 the middle estimate is 24-fold (1.39 log units) above the measured one, and the stated range ends above it.
By their numbers in this assay, from the lowest: compound 4; then compound 2; then compounds 1 and 3 (each within the scatter of the next).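

Going by these compounds alone, the oxygen on the aromatic ring turns out to be a sensitive position, which the earlier steps, all confined to the amine side, could not show: capping the hydroxy as methoxy gives a 24-fold lower number from compound 1 to compound 4 (1.38 log units; beyond the scatter). Compound 4 thus shows that the free hydroxy hydrogen is not needed for inhibition of this enzyme, at least with the but-2-yn-1-yl amine. No evidence is available on what lies behind this step. As far as these compounds go, whether methoxy brings a similar step on the propargyl amines of compound 2 and compound 3 remains open. So does the outcome of a longer chain on that oxygen, such as ethoxy.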